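Replacing an Aminophenyl with a Dichlorophenyl on the Carbonyl

The compounds below may be only part of what the source reports. "The series", "measured", "known", "first", "only" and "open" are said of these compounds alone.

Compound 1 `COc1cc(-c2cc(/C=C/C(=O)c3ccc(N)cc3)[nH]n2)cc(OC)c1OC` was tested in a functional assay on SF-268 cells (Homo sapiens) for cytotoxicity, read by sulforhodamine B assay, with a stated time of 48 h, tested at 100 uM (a lower number here means a stronger effect, a higher number a weaker effect of the compound at the concentration tested), where compound 1 gives -80%. Among the two numbers recorded this is the lowest; the nearest is compound 2 `COc1ccc(-c2cc(/C=C/C(=O)c3ccc(OC)c(OC)c3)[nH]n2)cc1`, which in this assay gives -63%, a higher number by a margin beyond the usual scatter. Compound 3 `COc1cc(-c2cc(/C=C/C(=O)c3ccc(Cl)c(Cl)c3)[nH]n2)cc(OC)c1OC` has not yet been measured. It differs from compound 1 in one place: 3,4-dichlorophenyl in place of 4-aminophenyl on a carbonyl carbon. Going by the values given here, no pair of measured compounds differs in only one place, so no measured step shows how such a change plays out in this assay. The author expects compound 3 to give a somewhat higher number than compound 1, a step of a number 15 percentage points higher from compound 1 to compound 3 (beyond the scatter) that may or may not exceed the scatter. The estimated value for compound 3 in this assay is -65%, with a range from -90% to -30%.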

Compound 3, a percentage reported as activity, at one concentration (the size of the read-out at that concentration, not a potency): -15%
Beside the measured number, compound 3's estimate is 50 percentage points below it; the whole stated range lies below it.
By their numbers in this assay, from the lowest: compound 1; then compound 2; then compound 3.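

Going by these compounds alone, on the carbonyl carbon of the core of compound 1, this is the first change in a single place that can be read in this assay: 3,4-dichlorophenyl in place of 4-aminophenyl gives a number 65 percentage points higher from compound 1 to compound 3 (beyond the scatter). The group at this place therefore matters a great deal, as the effect at the concentration tested weakens well beyond the scatter while the rest of the molecule stays the same. No measurement at hand explains the size of this step.

The compounds shown leave open whether the weaker effect of compound 3 goes with losing the amine or with gaining the two chlorines, as this one step changes both together. A plain phenyl or a monochlorophenyl on the same carbonyl carbon would help to separate the two.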